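This account rests on a few compounds, and the source may have more. Where it says the series, first, only, none or still open, it means among the compounds named here.

Measured compounds in a functional assay on MCF7 cells (Homo sapiens) for cytotoxicity, read by MTT assay, with a stated time of 72 h, tested at 1 uM; a lower number here means less inhibition of growth, a higher number more inhibition of growth at the concentration tested:
- compound 1 `N/C(=N\NC(=S)N1CCCC1)c1ccc(F)cn1` gives 51%
- compound 2 `Cc1cccc(/C(N)=N/NC(=S)N2CCOCC2)n1` gives 11.7%

Compound 1 stands highest of the two numbers; compound 2 is the nearest and sits well below it, beyond the scatter. Compound 2 differs from compound 1 in two places at once, so its lower number cannot be tied to either change alone; only the two values themselves are known.

Compound 3 `N/C(=N\NC(=S)N1CCSCC1)c1ccc(F)cn1` has not yet been measured. It differs from compound 1 in one place: thiomorpholin-4-yl in place of pyrrolidin-1-yl on a thiocarbonyl carbon. Going by the values given here, no step between measured compounds isolates this kind of change. Compound 2, which also carries a six-membered ring with two hetero atoms on the thiocarbonyl carbon, shows a much lower number than compound 1, but its second difference leaves the cause open. A moderate fall beyond the scatter, or none at all, is therefore expected for compound 3, with the step of a number 13 percentage points lower from compound 1 to compound 3 (beyond the scatter) as the estimate. Compound 3 is expected to give about 38%, likely between 12% and 62%.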

Compound 3, percent growth inhibition at one concentration: 30.6%
The estimate for compound 3 lay 7.4 percentage points above the measured number, and the stated range covers the measured number.
By their numbers in this assay, from the lowest: compound 2; then compound 3; then compound 1.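

In this assay, the group on the thiocarbonyl carbon now has an effect that can be read on its own: with the rest of compound 1 unchanged, thiomorpholin-4-yl in place of pyrrolidin-1-yl gives a number 20.4 percentage points lower from compound 1 to compound 3 (beyond the scatter). Compound 2 could not show this, as it differs from compound 1 in two places at once. No measurement at hand says what lies behind this step.

Ring size and the sulfur atom change together in this single step, so the compounds shown do not separate them, and a piperidin-1-yl group on the same thiocarbonyl carbon would be one way to pull the two apart. On these data alone, it also remains open how an open-chain dimethylamino group would compare there, and whether the same exchange gives a similar step on the core of compound 2.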